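A few compounds are considered here, and "the series" means these few. Any claim that something is new, unique, unknown or untested is made for them only; others in the source may bear on it.

Measured so far:

Compound 1 `Nc1nc(Cl)c(-c2nc3ccccc3o2)c(N[C@@H]2C[C@H](CO)[C@@H](O)[C@H]2O)n1`: in an ADME assay on cells (Homo sapiens) for cytotoxicity, read by polymerase chain reaction, with a stated time of 3 days (on this read-out higher numbers stand for lower toxicity in this test and lower numbers for higher toxicity in this test), compound 1 gives 12000 nM.
Compound 2 `Cc1nc(NCC(C)C)nc(N[C@@H]2C[C@H](CO)[C@@H](O)[C@H]2O)c1-c1nc2ccccc2s1`: in this assay compound 2 gives 10000 nM.

Compound 2 holds the lower of the two numbers recorded so far, but its nearest neighbour, compound 1, sits only a little higher and the gap between them lies within the scatter of the assay, so the two values are treated as equivalent. Among the measured compounds shown here, no pair of measured compounds differs in a single place, so there is no measured step to lean on.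

Compound 3 `Cc1nc(NCCCC(F)(F)F)nc(N[C@@H]2C[C@H](CO)[C@@H](O)[C@H]2O)c1-c1nc2ccccc2s1` has not yet been measured. It differs from compound 2 in one place: 3,3,3-trifluoropropyl in place of isopropyl on a saturated chain carbon bound to a nitrogen on an aromatic ring. For the measured compounds named here, no measured step of this kind exists, so the step from compound 2 to compound 3 is expected to be small: a 1.1-fold lower number from compound 2 to compound 3 (0.05 log units; within the scatter), a step not beyond the scatter in either direction. Compound 3 is therefore estimated at 9000 nM, with a range from 3000 nM to 30000 nM.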

Compound 3, half-maximal cytotoxic concentration: 3000 nM
For compound 3 the middle estimate is 3.0-fold (0.48 log units) above the measured one; low and high end bracket the measured number.
By their numbers in this assay, from the lowest: compound 3; then compounds 2 and 1 (each within the scatter of the next).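

The place on a saturated chain carbon bound to a nitrogen on an aromatic ring is now shown to matter in this assay: replacing isopropyl with 3,3,3-trifluoropropyl gives a 3.3-fold lower number from compound 2 to compound 3 (0.52 log units; beyond the scatter). Among the compounds shown here, this is the first single change with a readable step, and it points towards higher toxicity in this test, so the group at this place cannot be treated as neutral for this read-out. No available evidence bears on the origin of this step.

The compounds shown leave open whether the step follows the fluorine atoms or the chain itself, a question that a plain butyl chain at this place would address. They also leave open how an amine or a carboxylic acid carried on this chain would read in this assay.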